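Extending the dimethylamino tail: cytotoxicity notes

This account rests on a few compounds, and the source may have more. Where it says the series, first, only, none or still open, it means among the compounds named here.

Compound 1 `Cc1ccc2oc(-c3ccc(NC(=O)CN4CCN(CCN(C)C)CC4)cc3)nc2c1` is the reference point of this set. In an ADME assay on NIH3T3 cells (Mus musculus) for cytotoxicity, read by MTT assay, with a stated time of 24 h (on this read-out higher numbers stand for weaker inhibition and lower numbers for stronger inhibition), compound 1 gives 28900 nM. Compound 3 `Cc1ccc2oc(-c3ccc(NC(=O)CN4CCN(CCCN(C)C)CC4)cc3)nc2c1` carries the change (dimethylamino)methyl in place of dimethylamino on a saturated chain carbon, two bonds along the chain from an amine nitrogen in a ring and in this assay compound 3 gives 26400 nM. The step of a 1.1-fold lower number from compound 1 to compound 3 (0.04 log units; within the scatter) is therefore small, and the two values should be read as alike rather than as a change.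

Compound 2 `Cc1cc(-c2nc3cc(Cl)ccc3o2)ccc1NC(=O)CN1CCN(CCN(C)C)CC1` has a different core; how the core of compound 2 differs from the core of compound 1 is not broken down here. In this assay compound 2 gives 19200 nM. Set against compound 3 and compound 1, the values of compound 2 lie within the scatter of both, so no ordering among the three is claimed.

Compound 4 `Cc1cc(-c2nc3cc(Cl)ccc3o2)ccc1NC(=O)CN1CCN(CCCN(C)C)CC1` has not yet been measured. Within the data shown here, it differs from compound 2 by (dimethylamino)methyl in place of dimethylamino on a saturated chain carbon, two bonds along the chain from an amine nitrogen in a ring, which is the same change, at the same place, as the one from compound 1 to compound 3; the change thus appears in two pairs of this set. Among the measured compounds shown here, with only one measured instance to lean on, the expectation is that compound 4 sits close to compound 2, because a 1.1-fold lower number from compound 1 to compound 3 (0.04 log units; within the scatter) hardly moved the number. The step expected from compound 2 to compound 4 in this assay is a 1.1-fold lower number from compound 2 to compound 4 (0.04 log units; within the scatter). For compound 4 in this assay the estimated value is 17500 nM, expected to fall between 8500 nM and 36000 nM.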

Compound 4, half-maximal inhibitory concentration: 28600 nM
Estimate against measurement, compound 4: 1.6-fold (0.21 log units) below, and the stated range covers the measured number.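

On the core of compound 2, the change of dimethylamino to (dimethylamino)methyl gives a 1.5-fold higher number from compound 2 to compound 4 (0.17 log units; within the scatter) in this assay, so this step, like the earlier one on the core of compound 1, stays inside the usual scatter. The two steps cannot be told apart, and in these two pairs the change carries from one core to the other without a detectable difference: the same change on two cores in this assay, a 1.1-fold lower number (0.04 log units; within the scatter) from compound 1 to compound 3 and a 1.5-fold higher number (0.17 log units; within the scatter) from compound 2 to compound 4, 1.6-fold (0.21 log units) apart, within the scatter of two such steps. This supports treating the change as neutral for cytotoxicity on these two cores only; it does not show that the change is neutral on other cores, and the opposite directions printed for the two steps carry no meaning at this size.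

The compounds shown cover only the 2-(dimethylamino)ethyl and 3-(dimethylamino)propyl tails, all with numbers in the same broad range, so it remains open whether a longer chain than 3-(dimethylamino)propyl would move the number beyond the scatter in this assay. Also open, from the compounds shown here alone, is how a primary amine or a carboxylic acid in place of dimethylamino would read in this assay, and whether the chain change stays as quiet on a third core.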